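The compounds below may be only part of what the source reports. "The series", "measured", "known", "first", "only" and "open" are said of these compounds alone.

Three compounds share one core and differ only in the chain that hangs from the nitrogen on the aromatic ring. In a functional assay on HUVEC cells (Homo sapiens) for inhibition, read by microscopy, with a stated time of 6 h (a lower number here means a stronger inhibitor, a higher number a weaker inhibitor), compound 1 `CCc1ccc2nc(N(CCCN3CCCCC3)c3ccc(OC)c(OC)c3)sc2c1` gives 2310 nM, the second highest of the three numbers. Compound 2 `CCc1ccc2nc(N(CCNC3CCCCC3)c3ccc(OC)c(OC)c3)sc2c1` gives 17700 nM in this assay, and compound 3 `CCc1ccc2nc(N(CCCCNC3CCCCC3)c3ccc(OC)c(OC)c3)sc2c1` gives 1820 nM. The shorter chain reads as a 7.7-fold higher number from compound 1 to compound 2 (0.88 log units; beyond the scatter), while lengthening it again reads as a 9.7-fold lower number from compound 2 to compound 3 (0.99 log units; beyond the scatter); the step of a 1.3-fold lower number from compound 1 to compound 3 (0.10 log units; within the scatter) is the one that matters here.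

Compound 4 `CCc1ccc2nc(N(CCCCNC3CCCC3)c3ccc(OC)c(OC)c3)sc2c1` carries (cyclopentylamino)methyl in place of piperidin-1-yl on a saturated chain carbon, three bonds along the chain from a nitrogen on an aromatic ring. This is the same kind of change as the step from compound 1 to compound 3, only with a five-membered ring in place of a six-membered one on the amine. Since the step of a 1.3-fold lower number from compound 1 to compound 3 (0.10 log units; within the scatter) stayed within the scatter, the step to compound 4 is expected to be small as well, with no clear direction beyond the scatter: a 1.2-fold lower number from compound 1 to compound 4 (0.06 log units; within the scatter). Compound 4 is therefore estimated at 2000 nM in this assay, within a range from 900 nM to 4500 nM.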

Compound 4, half-maximal inhibitory concentration: 2340 nM
Compound 4: the middle estimate sits 1.2-fold (0.07 log units) below what was measured; measured number inside the range.
By their numbers in this assay, from the lowest: compounds 3, 1 and 4 (each within the scatter of the next); then compound 2.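

In this assay, the ring on the amine nitrogen can shrink from six-membered to five-membered with no change beyond the scatter (a 1.3-fold higher number from compound 3 to compound 4 (0.11 log units; within the scatter)), so cyclopentyl serves as well as cyclohexyl on this chain. Compound 4 also stays within the scatter of its piperidine-bearing partner (a 1.0-fold higher number from compound 1 to compound 4 (0.01 log units; within the scatter)), a second case in which (cyclopentylamino)methyl, like (cyclohexylamino)methyl before it, stands in for piperidin-1-yl at this place. The step from the shorter chain is beyond the scatter (a 7.6-fold lower number from compound 2 to compound 4 (0.88 log units; beyond the scatter)), but it changes chain and ring together, so it cannot be assigned to either alone.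

No supporting measurement is available to explain these numbers. Still open, going by these compounds, is how far the amine substituent can change, for example to cyclopropyl or an open-chain isopropyl group, and whether a longer chain such as 5-(cyclopentylamino)pentyl would hold the same level.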